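Halogen swap at the phenolic ring: chloro to iodo

The compounds below may be only part of what the source reports. "The series", "measured", "known", "first", "only" and "open" are said of these compounds alone.

Compound 1 `COc1cc(CNC(=S)NCC(COC(=O)C(C)(C)C)Cc2ccc(C)c(C)c2)ccc1O` and compound 3 `COc1cc(CNC(=S)NCC(COC(=O)C(C)(C)C)Cc2ccc(C)c(C)c2)cc(Cl)c1O` carry the same core; in a functional assay on CHO cells for antagonist activity at transient receptor potential cation channel subfamily V member 1 (Rattus norvegicus) (a lower number here means a stronger inhibitor, a higher number a weaker inhibitor), compound 1 gives "not evaluated" (no result reported) and compound 3 gives "not evaluated" (no result reported), so neither has a reported number. The only figure in this series comes from compound 2 `COc1cc(CNC(=S)NCC(COC(=O)C(C)(C)C)Cc2ccc(C(C)(C)C)cc2)c(I)cc1O`, which differs in more than one place and in this assay gives 71 nM. Among the compounds with values here, compound 3 therefore stands without a number of its own, so no step can be computed toward compound 4 `COc1cc(CNC(=S)NCC(COC(=O)C(C)(C)C)Cc2ccc(C)c(C)c2)cc(I)c1O`. The change iodo in place of chloro on an aromatic carbon is iodo in place of chloro on an aromatic carbon, ortho to a hydroxy group and meta to a methoxy group. Compound 4 is expected, given compound 2 at 71 nM, to fall near 100 nM, within 20 nM to 500 nM.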

Compound 4, inhibition constant: 121 nM
Compound 4: middle estimate off by 1.2-fold (0.08 log units), on the low side, and the stated range covers the measured number.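

Within the data shown here, with no single number for compound 3 in this assay, no step to compound 4 can be read. The compounds shown leave open how iodo in place of chloro alters inhibition. No evidence bears on this result.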